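Replacing a Chlorinated Aromatic Ring with a Seven-Membered Ring

The compounds below may be only part of what the source reports. "The series", "measured", "known", "first", "only" and "open" are said of these compounds alone.

Measured so far:
compound 1 `c1ccc2c(c1)CCC(CNCCCNc1ccncn1)O2` — 10 nM
compound 2 `Clc1ccc(NCCCNCC2CCc3ccccc3O2)nn1` — 2 nM

Of the compounds shown here, two have been tested in an assay on isolated protein (Bos taurus) with 5-hydroxytryptamine receptor 1D (Homo sapiens) as the target; a higher number here means a weaker inhibitor, a lower number a stronger inhibitor. Compound 1 gives 10 nM, and compound 2 gives 2 nM. Within the data shown here, the one step between them, a 5.0-fold lower number from compound 1 to compound 2 (0.70 log units; beyond the scatter), is the only measured change here, so compound 2 stands as the lower of the two numbers, beyond the scatter from compound 1.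

Compound 3 `O=C1CCCN=C(NCCCNCC2CCc3ccccc3O2)N1` has not been measured. It differs from compound 2 as follows: a group of 8 heavy atoms (5 carbon, 2 nitrogen, 1 oxygen; one seven-membered non-aromatic ring with 2 hetero atoms) in place of a group of 7 heavy atoms (4 carbon, 2 nitrogen, 1 chlorine; one six-membered aromatic ring with 2 hetero atoms), on an amine nitrogen. Among the measured compounds shown here, no measured step covers a change of this kind: the only known step, a 5.0-fold lower number from compound 1 to compound 2 (0.70 log units; beyond the scatter), exchanged one six-membered aromatic ring for another, whereas here an aromatic ring gives way to a non-aromatic one. The direction of the effect is therefore open, and the uncertainty is wide. The estimated value for compound 3 in this assay is 10 nM, with a range from 2 nM to 60 nM. This corresponds to an expected step of a 5.0-fold higher number from compound 2 to compound 3 (0.70 log units; beyond the scatter).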

Compound 3, half-maximal inhibitory concentration: 158 nM
Beside the measured number, compound 3's estimate is 16-fold (1.20 log units) below it; measured number outside the range, above it.
By their numbers in this assay, from the lowest: compound 2; then compound 1; then compound 3.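

In this assay, the group on this amine nitrogen proves far less forgiving than the earlier pair suggested: putting the seven-membered non-aromatic ring in place of 6-chloropyridazin-3-yl gives a 79-fold higher number from compound 2 to compound 3 (1.90 log units; beyond the scatter) and this is a much larger change than a 5.0-fold lower number from compound 1 to compound 2 (0.70 log units; beyond the scatter) seen between the two aromatic rings. The same ring also compares poorly with pyrimidin-4-yl, giving a 16-fold higher number from compound 1 to compound 3 (1.20 log units; beyond the scatter) and so both six-membered aromatic rings shown give lower numbers than it does. Nothing available explains this loss.

Compound 3 changes ring size, aromatic character and the carbonyl all at once, so the compounds shown cannot separate these changes. A pyridine or a plain phenyl ring on the same amine nitrogen would show how much the ring nitrogens and the chlorine contribute.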